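The source may report more compounds than this note shows. Statements on the series, on what has been measured and on what is new or still open speak of the compounds shown alone.

Measured compounds in a functional assay on A549 cells (Homo sapiens) for antiproliferative activity, read by MTT assay, with a stated time of 48 h; on this read-out lower numbers stand for stronger inhibition and higher numbers for weaker inhibition:
Compound 1 `O=c1cc(-n2cc(CSc3ccccc3)nn2)c2cc(Br)ccc2o1`: in this assay compound 1 gives 3510 nM.
Compound 2 `O=c1cc(-n2cc(COc3ccccc3)nn2)c2cc(Br)ccc2o1`: in this assay compound 2 gives 12300 nM.

Compound 2 stands at the higher of the two numbers in this assay. For the measured compounds named here, its nearest neighbour is compound 1, and the only measured step, a 3.5-fold higher number from compound 1 to compound 2 (0.54 log units; beyond the scatter), runs between them; that step exchanges phenylsulfanyl for phenoxy on the saturated chain carbon and leaves the phenyl ring itself untouched.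

Compound 3 `COC(=O)c1ccccc1OCc1cn(-c2cc(=O)oc3ccc(Br)cc23)nn1` differs from compound 2 in one place: methoxycarbonyl in place of hydrogen on an aromatic carbon. Going by the values given here, no measured step bears on a substituent entering the phenyl ring. The step of a 3.5-fold higher number from compound 1 to compound 2 (0.54 log units; beyond the scatter) concerns the chain and not the ring, so it offers no guide, and the data hold nothing else. The expectation for compound 3 in this assay therefore rests on compound 2 alone, with no direction favoured and a wide range on both sides; the step of a 1.1-fold lower number from compound 2 to compound 3 (0.05 log units; within the scatter) is expected to stay within the scatter. Compound 3 is estimated at 11000 nM, with a range from 3500 nM to 35000 nM.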

Compound 3, half-maximal inhibitory concentration: 5250 nM
Compound 3: middle estimate off by 2.1-fold (0.32 log units), on the high side; measured number inside the range.
By their numbers in this assay, from the lowest: compounds 1 and 3 (each within the scatter of the next); then compound 2.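

In this assay, for the compounds shown here, methoxycarbonyl in place of hydrogen gives a 2.3-fold lower number from compound 2 to compound 3 (0.37 log units; beyond the scatter) and is the first measured change on the phenyl ring itself, as opposed to the chain that links it to the shared core. The carbon ortho to a large group on this ring therefore accepts methoxycarbonyl, and the number moves beyond the scatter towards stronger inhibition, though the step is modest in size. With only this one substituent at this one place, the step shows a single tolerated change and not a trend across the ring. Nothing available accounts for this step.

The compounds shown leave open whether the lower number belongs to methoxycarbonyl specifically or would also appear with a carboxylic acid, a primary amide or a simple methyl group at the same carbon. They also leave open whether methoxycarbonyl would act in the same way on other carbons of the ring, or on the phenyl ring of the phenylsulfanyl compound 1.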